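Moving methoxy groups on the dimethoxyphenyl ring

The source may hold more compounds than are shown below. What is called first, only, known or untested is meant among the compounds shown, and "the series" means these compounds.

Measured in a functional assay on A549 cells (Homo sapiens) for inhibition, read by sulforhodamine B assay, with a stated time of 48 h; a lower number here means a stronger inhibitor of growth, a higher number a weaker inhibitor of growth:
- compound 1 `COc1ccc(/C=C/C(=O)C(=Cc2cc(OC)c(OC)c(OC)c2)C(=O)/C=C/c2ccc(OC)c(OC)c2)cc1OC`: 230 nM
- compound 2 `COc1ccc(/C=C/C(=O)C(=Cc2cccc(OC)c2OC)C(=O)/C=C/c2ccc(OC)c(OC)c2)cc1OC`: 670 nM

Of these two measured compounds, compound 2 has the higher number, at 670 nM, and is therefore the weaker inhibitor of growth in this assay. Going by the values given here, the only measured step is a 2.9-fold higher number from compound 1 to compound 2 (0.46 log units; beyond the scatter). It is modest but beyond the scatter, and it replaces 3,4,5-trimethoxyphenyl with 2,3-dimethoxyphenyl at the same place.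

The next change leads to compound 3 `COc1ccc(OC)c(C=C(C(=O)/C=C/c2ccc(OC)c(OC)c2)C(=O)/C=C/c2ccc(OC)c(OC)c2)c1`: 2,5-dimethoxyphenyl in place of 2,3-dimethoxyphenyl on a double-bonded chain carbon bound to a double-bonded chain carbon. Here 2,5-dimethoxyphenyl stands in place of 2,3-dimethoxyphenyl on a double-bonded chain carbon bound to a double-bonded chain carbon. The two structures have the same atoms, joined differently, whereas the measured step also changed the substituent count. Among the compounds with values here, that step therefore bears on this change only loosely, and no measured pair compares dimethoxyphenyl isomers. No step beyond the scatter is expected in this assay, and the data favour no firm direction. The estimated step is a 1.1-fold lower number from compound 2 to compound 3 (0.05 log units; within the scatter). For compound 3 the expected value is 600 nM, with an estimated range from 250 nM to 1500 nM.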

Compound 3, concentration for 50% growth inhibition: 530 nM
Beside the measured number, compound 3's estimate is 1.1-fold (0.05 log units) above it; the measured number falls inside the stated range.
By their numbers in this assay, from the lowest: compound 1; then compounds 3 and 2 (each within the scatter of the next).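

In this assay, going by these compounds alone, this is the first comparison between two dimethoxyphenyl isomers at this place on the chain. It gives a 1.3-fold lower number from compound 2 to compound 3 (0.10 log units; within the scatter) and so shows no separation between 2,3-dimethoxyphenyl and 2,5-dimethoxyphenyl, at least for this pair of arrangements. The second dimethoxyphenyl isomer also stays apart from the 3,4,5-trimethoxyphenyl compound, with a 2.3-fold higher number from compound 1 to compound 3 (0.36 log units; beyond the scatter) alongside the earlier 2.9-fold higher number from compound 1 to compound 2 (0.46 log units; beyond the scatter), so among these three compounds the lowest number belongs to compound 1 and neither dimethoxyphenyl isomer matches it. Nothing available here accounts for either the gap to compound 1 or the closeness of the two isomers.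

The compounds shown leave open whether the gap to compound 1 follows the third methoxy group itself or the places the methoxy groups occupy, since both dimethoxyphenyl changes alter the count and the arrangement together. Also open, going by these compounds, is how this place on the chain responds to groups other than methoxy on the ring, such as an amine, a carboxylic acid or a longer ether chain like ethoxy.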